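Swapping cyclopropylmethyl for fluorophenyl: cytotoxicity in liver cells

The compounds below may be only part of what the source reports. "The series", "measured", "known", "first", "only" and "open" are said of these compounds alone.

The measured compounds, all tested in an ADME assay on Huh-7 cells (Homo sapiens) for cytotoxicity, with a stated time of 72 h; a higher number here means that more compound is tolerated, a lower number that less compound is tolerated:
Compound 1, `CS(=O)(=O)Nc1ccc2c(c1)S(=O)(=O)N=C(C1=C(O)C3CCCC3N(CCC3CC3)C1=O)N2`, gives > 33000 nM, which is a limit of the assay rather than a number.
Compound 2, `CS(=O)(=O)Nc1ccc2c(c1)S(=O)(=O)N=C(C1=C(O)[C@H]3CCC[C@H]3N(Cc3ccc(F)c(Cl)c3)C1=O)N2`, gives > 1000 nM, again a limit.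
Compound 3, `CS(=O)(=O)Nc1ccc2c(c1)S(=O)(=O)N=C(C1=C(O)[C@H]3CCC[C@H]3N(Cc3cccc(C(F)(F)F)c3)C1=O)N2`, gives > 33000 nM, also a limit.

For the measured compounds named here, compound 1 therefore stands only at a limit in this assay, and so do the two other values shown; no compound in this set has a measured number. Going by the values given here, the one change between measured compounds, a step that the two limits leave unreadable from compound 2 to compound 3, cannot be read because the limit of > 1000 nM in this assay, at which 1 of the 3 values shown sits, and the limit of > 33000 nM in this assay, at which 2 of the 3 values shown sit, are both limits and the true values behind them are unknown.

The compound not yet measured is compound 4, `CS(=O)(=O)Nc1ccc2c(c1)S(=O)(=O)N=C(C1=C(O)C3CCCC3N(Cc3cccc(F)c3)C1=O)N2`. From compound 1 it differs by 3-fluorophenyl in place of cyclopropylmethyl on a saturated chain carbon bound to an amide-type nitrogen in a ring. Among the compounds with values here, no measured step bears directly on this change, and the one step that is known is unreadable, so there is no basis to expect a shift beyond the scatter in either direction.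

Compound 4 is therefore expected to sit at about 40000 nM, within a range of 12000 nM to 100000 nM, which is an estimated step that the limit leaves unreadable from compound 1 to compound 4.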

Compound 4, half-maximal cytotoxic concentration: > 33000 nM
Compound 4 was reported as a limit; the forecaster's own chance of this, stated with the estimate: 80%; the middle value lies beyond the limit too.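

Compound 1 and compound 4 both stand at a limit of the assay rather than at a number, so the step between them cannot be read: the limit of > 33000 nM in this assay, at which 3 of the 4 values shown sit.

The compounds shown leave open how much of any of them is actually tolerated in this assay, and whether 3-fluorophenyl in place of cyclopropylmethyl changes that at all.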